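Methyl in place of hydrogen: expectation for compound 3

The compounds below may be only part of what the source reports. "The series", "measured", "known", "first", "only" and "open" are said of these compounds alone.

Measured in a functional assay on the whole organism for positive allosteric modulation, with Rattus norvegicus as the target; a lower number here means that less compound is needed, a higher number that more compound is needed for the effect:
compound 1 `Cc1nn(C)c2c1C(c1cccc(Cl)c1)=NCCN2`: 0.63 mg/kg
compound 2 `CCN1CCN=C(c2cccc(Cl)c2)c2c(C)nn(C)c21`: 0.63 mg/kg

For the measured compounds named here, compound 1 stands level with compound 2 within the scatter; the only measured step, no change at the digits printed from compound 1 to compound 2 (within the scatter), shows ethyl in place of hydrogen on a nitrogen on an aromatic ring in a ring. Compound 3 `Cc1nn(C)c2c1C(c1cccc(Cl)c1C)=NCCN2` differs from compound 1 by methyl in place of hydrogen on an aromatic carbon. Going by the values given here, no measured step touches an aromatic carbon of the six-membered aromatic ring of carbon only, so that single step bears only loosely on this change, and nothing here points to a shift in either direction. In this assay compound 3 is expected to give 0.63 mg/kg, between 0.3 mg/kg and 1.3 mg/kg. The expected step of no change at the digits printed from compound 1 to compound 3 (within the scatter) is none beyond the scatter.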

Compound 3, minimum effective dose: 1.25 mg/kg
Estimate against measurement, compound 3: 2.0-fold (0.30 log units) below; the range from low to high includes it.
By their numbers in this assay, from the lowest: compounds 1, 2 and 3 (each within the scatter of the next).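

In this assay, for the compounds shown here, methyl in place of hydrogen on an aromatic carbon ortho to a chloro group gives the first reading on the six-membered aromatic ring of carbon only: a 2.0-fold higher number from compound 1 to compound 3 (0.30 log units; within the scatter). This position therefore takes one added carbon with no shift that stands clear of the scatter. Nothing available explains the result at the level of mechanism.

Still open, on these data alone, is whether a longer chain, a methoxy group or an amine on this same carbon would keep the dose level in this assay. Also open, as far as these compounds go, is how a nitrile in place of the chloro group would read there.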